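Cyclopropylmethyl on the ring amine: an expected small step

A few compounds are considered here, and "the series" means these few. Any claim that something is new, unique, unknown or untested is made for them only; others in the source may bear on it.

Compound 3 `CN(C(=O)N1CC[C@H](n2cnc3cc(-c4ccc(Cl)cc4)sc3c2=O)C1)[C@H]1CCN(C2CCC(C)(C)CC2)C1` carries a 4,4-dimethylcyclohexyl group on an amine nitrogen in a ring of the shared core. In a functional assay for antagonist activity at melanin-concentrating hormone receptor 1 (Homo sapiens), read by GTPgammaS binding (a lower number here means a stronger inhibitor, a higher number a weaker inhibitor), compound 3 gives 10 nM, the second highest of the three numbers measured. Its nearest neighbour is compound 2 `CN(C(=O)N1CC[C@H](n2cnc3cc(-c4ccc(Cl)cc4)sc3c2=O)C1)[C@H]1CCN(C2CCC2)C1`, which bears cyclobutyl on that nitrogen and in this assay gives 9 nM; the gap, a 1.1-fold higher number from compound 2 to compound 3 (0.05 log units; within the scatter), is within the scatter. The furthest is compound 1 `CN(C(=O)N1CC[C@H](n2cnc3cc(-c4ccc(Cl)cc4)sc3c2=O)C1)[C@H]1CCNC1`, with hydrogen on that nitrogen, which in this assay gives 29 nM.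

Compound 4 `CN(C(=O)N1CC[C@H](n2cnc3cc(-c4ccc(Cl)cc4)sc3c2=O)C1)[C@H]1CCN(CC2CC2)C1` differs from compound 3 in one place: cyclopropylmethyl in place of 4,4-dimethylcyclohexyl on an amine nitrogen in a ring.

Among the compounds with values here, two measured steps bear on this change. Replacing the hydrogen of compound 1 by either ring group lowered the number to a similar degree, a 3.2-fold lower number from compound 1 to compound 2 (0.51 log units; beyond the scatter) and a 2.9-fold lower number from compound 1 to compound 3 (0.46 log units; beyond the scatter), while the exchange of one ring group for the other, a 1.1-fold higher number from compound 2 to compound 3 (0.05 log units; within the scatter), stayed within the scatter. Compound 4 again carries a carbon-only group on that nitrogen, so no step beyond the scatter is expected in this assay, no change at the digits printed from compound 3 to compound 4 (within the scatter). Compound 4 is therefore estimated at 10 nM, with a range from 4 nM to 25 nM.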

Compound 4, half-maximal inhibitory concentration: 10 nM
Estimate against measurement, compound 4: no gap at the digits printed, and the stated range covers the measured number.
By their numbers in this assay, from the lowest: compounds 2, 3 and 4 (each within the scatter of the next); then compound 1.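

In this assay, the step of no change at the digits printed from compound 3 to compound 4 (within the scatter) shows that the nitrogen of the five-membered ring tolerates a group of 4 heavy atoms as well as one of 8 heavy atoms, and that a three-membered ring reached through cyclopropylmethyl serves as well as the six-membered ring of 4,4-dimethylcyclohexyl. The comparison with cyclobutyl, a 1.1-fold higher number from compound 2 to compound 4 (0.05 log units; within the scatter), points the same way, so across these three carbon-only groups neither the ring size nor the heavy-atom count moves the number beyond the scatter. The gain over hydrogen also persists with this smallest of the three groups, at a 2.9-fold lower number from compound 1 to compound 4 (0.46 log units; beyond the scatter).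

No measurement shown here accounts for this flat response at the nitrogen. The compounds shown leave open whether an open chain such as ethyl, or a group carrying oxygen such as a carboxylic acid, on that nitrogen would give a number in line with compound 2, compound 3 and compound 4, or one closer to that of compound 1.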